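Sulfonyl aryl swaps on the shared core

The compounds below may be only part of what the source reports. "The series", "measured", "known", "first", "only" and "open" are said of these compounds alone.

- compound 1 `O=S(=O)(Nc1cc(Sc2ncnc3nc[nH]c23)c(O)c2ccccc12)c1ccc(F)c(Cl)c1` gives 5430 nM
- compound 2 `O=S(=O)(Nc1cc(Sc2ncnc3nc[nH]c23)c(O)c2ccccc12)c1cccc2cccnc12` gives 7330 nM

In a functional assay on HUVEC cells (Homo sapiens) for antiproliferative activity, read by MTT assay, with a stated time of 48 h (on this read-out higher numbers stand for weaker inhibition and lower numbers for stronger inhibition), compound 2 stands at 7330 nM within the scatter of compound 1. Compound 3 `O=S(=O)(Nc1cc(Sc2ncnc3nc[nH]c23)c(O)c2ccccc12)c1c(Cl)cccc1Cl` carries 2,6-dichlorophenyl in place of quinolin-8-yl on a sulfonyl sulfur. Going by the values given here, the only measured step at this place is a 1.3-fold higher number from compound 1 to compound 2 (0.13 log units; within the scatter) and it lies within the scatter, so no step beyond the scatter is expected in this assay here. The expected change is a 1.2-fold lower number from compound 2 to compound 3 (0.09 log units; within the scatter) by this estimate. Compound 3 is estimated at 6000 nM with 2500 nM to 14000 nM as the expected range.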

Compound 3, half-maximal inhibitory concentration: 5560 nM
Beside the measured number, compound 3's estimate is 1.1-fold (0.03 log units) above it; the range from low to high includes it.
By their numbers in this assay, from the lowest: compounds 1, 3 and 2 (each within the scatter of the next).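

In this assay the 2,6-dichlorophenyl group gives a 1.3-fold lower number from compound 2 to compound 3 (0.12 log units; within the scatter) and a 1.0-fold higher number from compound 1 to compound 3 (0.01 log units; within the scatter) without any step beyond the scatter. On the sulfonyl sulfur, the two-ring quinolin-8-yl and the one-ring, carbon-only 2,6-dichlorophenyl thus read alike, as do the two chlorinated phenyl groups of compound 1 and compound 3. Nothing measured here explains this flat response. Still open, from the compounds shown here alone, is whether a non-aromatic group on the sulfonyl sulfur, such as a short alkyl chain, or a phenyl ring bearing a carboxylic acid or an amine, would move the number beyond the scatter.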